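Working notes: from compound 2 to compound 4

A few compounds are considered here, and "the series" means these few. Any claim that something is new, unique, unknown or untested is made for them only; others in the source may bear on it.

Measured in a functional assay on K562 cells (Homo sapiens) for inhibition, read by MTT assay, with a stated time of 48 h; on this read-out higher numbers stand for weaker inhibition and lower numbers for stronger inhibition
- compound 1 `CC(C)(C)OC(=O)N1C[C@@H](n2cc(-c3ccc4c(N)n[nH]c4c3)nn2)C[C@H]1C(=O)Nc1ccc(Cl)cc1Cl` gives 12200 nM
- compound 2 `Nc1n[nH]c2cc(-c3cn([C@@H]4CN[C@H](C(=O)Nc5ccc(Cl)c(C(F)(F)F)c5)C4)nn3)ccc12` gives 8320 nM
- compound 3 `O=C(Nc1n[nH]c2cc(-c3cn([C@@H]4CN[C@H](C(=O)Nc5ccc(Cl)c(C(F)(F)F)c5)C4)nn3)ccc12)C1CC1` gives 5200 nM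

Compound 2 at 8320 nM lies within the scatter of both compound 1 and compound 3, so the three numbers give it no clear rank. Compound 4 `Nc1n[nH]c2cc(-c3cn([C@@H]4CN[C@H](C(=O)Nc5ccc(Cl)cc5Cl)C4)nn3)ccc12` carries 2,4-dichlorophenyl in place of 4-chloro-3-(trifluoromethyl)phenyl on an amide-type nitrogen and is otherwise the same as compound 2.

Going by the values given here, no measured step covers this exchange directly. Among the compounds with values here, the one measured step, a 1.6-fold lower number from compound 2 to compound 3 (0.20 log units; within the scatter), lies within the scatter, but it concerns a nitrogen on an aromatic ring and not the amide-type nitrogen, so it shows only that one change elsewhere on compound 2 left the number within the scatter. Within the data shown here, compound 1 is the only measured compound with the 2,4-dichlorophenyl group and gives 12200 nM, but it also differs from compound 4 at another place, so it is only a loose guide. In this assay no step beyond the scatter is expected, and the estimated change is a 1.1-fold higher number from compound 2 to compound 4 (0.03 log units; within the scatter), with the direction left open. Compound 4 is expected at 9000 nM (estimated range 3500 nM to 22000 nM).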

Compound 4, half-maximal inhibitory concentration: 28400 nM
The estimate for compound 4 lay 3.2-fold (0.50 log units) below the measured number; the whole stated range lies below it.
By their numbers in this assay, from the lowest: compounds 3, 2 and 1 (each within the scatter of the next, the first and the last beyond it); then compound 4.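

On the amide-type nitrogen, 2,4-dichlorophenyl in place of 4-chloro-3-(trifluoromethyl)phenyl moves the number beyond the scatter in this assay (a 3.4-fold higher number from compound 2 to compound 4 (0.53 log units; beyond the scatter)), and the change is towards weaker inhibition, whereas the earlier change on the nitrogen on an aromatic ring stayed within it (a 1.6-fold lower number from compound 2 to compound 3 (0.20 log units; within the scatter)). With 2,4-dichlorophenyl held constant, the amine nitrogen in a ring also proves to be a place where the number responds, as hydrogen in place of tert-butoxycarbonyl also gives weaker inhibition (a 2.3-fold higher number from compound 1 to compound 4 (0.37 log units; beyond the scatter)). Nothing available accounts for either step, so both stand as observations on these compounds alone.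

On these data alone, the two chlorine-bearing aryl groups differ in more than one feature, so it remains open whether the step on the amide-type nitrogen follows from the loss of trifluoromethyl or from the second chlorine; a plain phenyl or a 4-chlorophenyl on that nitrogen would help to separate the two. Also open, as far as these compounds go, is whether tert-butoxycarbonyl has the same effect alongside 4-chloro-3-(trifluoromethyl)phenyl, and how an acetyl or a methyl on the amine nitrogen in a ring would compare with hydrogen.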